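Series notes: rearranged bicyclic ether, compound 2 to compound 3

This account rests on a few compounds, and the source may have more. Where it says the series, first, only, none or still open, it means among the compounds named here.

Measured so far:
- compound 1 `CN(c1ccc(Oc2ncnc3ccsc23)cc1)c1nccc(N2CCc3ccccc3C2)n1` gives 69.9% in a functional assay on A549 cells (Homo sapiens) for inhibition, read by MTT assay, with a stated time of 72 h, tested at 20 uM; on this read-out higher numbers stand for more inhibition at the one concentration tested (going by the name of the read-out) and lower numbers for less inhibition
- compound 2 `c1ccc2c(c1)CCN(c1ccnc(Nc3ccc(Oc4ncnc5ccsc45)cc3)n1)C2` gives 54.9% in this assay

Going by the values given here, compound 2 stands lowest of the two numbers in this assay; its only neighbour is compound 1, and the step of a number 15 percentage points lower from compound 1 to compound 2 (beyond the scatter) is the one measured step in the set and goes beyond the scatter. It concerns the hydrogen in place of methyl on a nitrogen on an aromatic ring and nothing else.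

Compound 3 `c1ccc2c(c1)CCN(c1ccnc(Nc3ccc(Oc4ncnc5sccc45)cc3)n1)C2` is the next member. It differs from compound 2 by a group of 9 heavy atoms (6 carbon, 2 nitrogen, 1 sulfur; one five-membered aromatic ring with 1 hetero atom, one six-membered aromatic ring with 2 hetero atoms) in place of a group of 9 heavy atoms (6 carbon, 2 nitrogen, 1 sulfur; one five-membered aromatic ring with 1 hetero atom, one six-membered aromatic ring with 2 hetero atoms), on an oxygen on an aromatic ring; the two have the same atoms, joined differently. Among the compounds with values here, no measured step touches this place on the oxygen on an aromatic ring, so the step of a number 15 percentage points lower from compound 1 to compound 2 (beyond the scatter) gives no guidance on its size or direction. With nothing to point either way, the expectation in this assay is a step no larger than the scatter, a number 0.1 percentage points higher from compound 2 to compound 3 (within the scatter), around the number of compound 2, with a wide range to reflect the absence of any comparable step.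

Compound 3 is therefore estimated at 55%, expected to lie between 35% and 75%.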

Compound 3, a percentage reported as inhibition, at one concentration (the size of the read-out at that concentration, not a potency): 34%
Compound 3: the middle estimate sits 21 percentage points above what was measured, outside the stated range (below it).
By their numbers in this assay, from the lowest: compound 3; then compound 2; then compound 1.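

The group on an oxygen on an aromatic ring turns out to matter in this assay: exchanging it for a group with the same atoms, the same two aromatic rings and the same counts of hydrogen-bond donors and acceptors gives a number 20.9 percentage points lower from compound 2 to compound 3 (beyond the scatter). Composition and these counts therefore do not settle the result at this position, and how the atoms are joined within the group is enough to move the number beyond the scatter. No supporting measurement is available that would account for this difference.

Still open, from the compounds shown here alone, is whether methyl in place of hydrogen on the nitrogen on an aromatic ring would act on compound 3 as it does in the step between compound 1 and compound 2, since the two changes are not seen together here. Also open, going by these compounds, is how the group on the oxygen would respond to a change of a different kind, for instance an amine or a carboxylic acid carried on it, as both compounds here bear only the two joined aromatic rings at this place.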